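Turning the methyl of compound 1 into (piperidin-1-yl)methyl

A few compounds are considered here, and "the series" means these few. Any claim that something is new, unique, unknown or untested is made for them only; others in the source may bear on it.

In a physicochemical assay for solubility, read by HPLC, in phosphate buffer, at pH 6.5 (a lower number here means a less soluble compound, a higher number a more soluble compound), compound 1 `COC(=O)C1=C(C)NC(c2nccs2)=NC1(C)c1ccc(F)cc1` gives 22 ug/mL, level with compound 2 `COC(=O)C1=C(C)NC(c2nccs2)=NC1(C)c1ccc(F)cc1Cl` at 18 ug/mL and clearly under compound 3 `COC(=O)C1=C(C)NC(c2nccs2)=NC1(C)c1ccc(C#N)cc1` at 87 ug/mL. Compound 4 `COC(=O)C1=C(CN2CCCCC2)NC(c2nccs2)=NC1(C)c1ccc(F)cc1` carries a new group on the methyl of compound 1: piperidin-1-yl in place of hydrogen on a saturated chain carbon bound to a double-bonded ring carbon. The chloro change, a 1.2-fold lower number from compound 1 to compound 2 (0.09 log units; within the scatter), stays within the scatter, while the cyano change, a 4.0-fold higher number from compound 1 to compound 3 (0.60 log units; beyond the scatter), goes beyond it. Both changes sit on an aromatic carbon, so neither tests this place, and they serve only as a gauge of size. Within the data shown here, no measured step shows the direction here, so a rise of similar size in this assay is a tentative expectation. The expected step is a 3.6-fold higher number from compound 1 to compound 4 (0.56 log units; beyond the scatter). Compound 4 is estimated at 80 ug/mL, with an expected range from 20 ug/mL to 300 ug/mL.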

Compound 4, solubility: 282 ug/mL
For compound 4 the middle estimate is 3.5-fold (0.55 log units) below the measured one; the range from low to high includes it.
By their numbers in this assay, from the lowest: compounds 2 and 1 (each within the scatter of the next); then compound 3; then compound 4.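

Among these compounds, this place on the shared core, which no earlier step tested, takes a much larger group and still gives a clear change. In this assay, piperidin-1-yl in place of hydrogen on this saturated chain carbon gives a 13-fold higher number from compound 1 to compound 4 (1.11 log units; beyond the scatter) and so moves the number further than either step made on an aromatic carbon. No measurement here bears on why the number rises.

The compounds shown leave open whether the rise depends on the whole piperidine ring or on its nitrogen. Dimethylamino or morpholin-4-yl on the same carbon would help separate the two.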